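The source may hold more compounds than are shown below. What is called first, only, known or untested is meant among the compounds shown, and "the series" means these compounds.

Three carbamates built on a shared core have been measured in an assay (strain Wistar) for inhibition of Fatty-acid amide hydrolase 1 (Rattus norvegicus); a higher number here means a weaker inhibitor, a lower number a stronger inhibitor. Compound 1 `CCCNC(=O)Oc1cccc(C(=O)c2nc3ccccc3o2)c1` gives 109 nM, compound 2 `O=C(NC1CCCCC1)Oc1cccc(C(=O)c2nc3ccccc3o2)c1` gives 47 nM, and compound 3 `O=C(NCc1ccccc1)Oc1cccc(C(=O)c2nc3ccccc3o2)c1` gives 152 nM. Compound 3 stands at the high end of these three numbers; one step, a 1.4-fold higher number from compound 1 to compound 3 (0.14 log units; within the scatter), lies within the scatter, while the other, a 3.2-fold higher number from compound 2 to compound 3 (0.51 log units; beyond the scatter), lies beyond it. Compound 4 `Cc1cccc(CNC(=O)Oc2cccc(C(=O)c3nc4ccccc4o3)c2)c1` differs from compound 3 in one place: methyl in place of hydrogen on an aromatic carbon. Among the compounds with values here, none of the measured steps touches an aromatic carbon in this way. The steps of a 2.3-fold lower number from compound 1 to compound 2 (0.37 log units; beyond the scatter), a 1.4-fold higher number from compound 1 to compound 3 (0.14 log units; within the scatter) and a 3.2-fold higher number from compound 2 to compound 3 (0.51 log units; beyond the scatter) each exchange the whole group on the amide-type nitrogen, and even those moved the numbers only modestly, so they set the scale rather than the direction here. Within the data shown here, with no step of the same kind to lean on, the number for compound 4 is expected to move little, a 1.0-fold lower number from compound 3 to compound 4 (0.01 log units; within the scatter), a step not expected to pass beyond the scatter in this assay. Compound 4 is therefore estimated at 150 nM, with a range from 60 nM to 400 nM.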

Compound 4, half-maximal inhibitory concentration: 32 nM
Beside the measured number, compound 4's estimate is 4.7-fold (0.67 log units) above it; measured number below the stated range.
By their numbers in this assay, from the lowest: compounds 4 and 2 (each within the scatter of the next); then compounds 1 and 3 (each within the scatter of the next).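

In this assay a single methyl on an aromatic carbon of the benzyl group gives a 4.8-fold lower number from compound 3 to compound 4 (0.68 log units; beyond the scatter) and so shows that this position on the ring is sensitive: one added heavy atom moves the number about as far as exchanging the whole group on the amide-type nitrogen did. The 3-methylbenzyl group also changes how the nitrogen substituents compare, with a 1.5-fold lower number from compound 2 to compound 4 (0.17 log units; within the scatter) leaving compound 4 level with the cyclohexyl compound, while a 3.4-fold lower number from compound 1 to compound 4 (0.53 log units; beyond the scatter) sets it clearly apart from the propyl compound. No evidence is available that explains this gain.

The compounds shown leave open whether the gain is specific to methyl or would also appear with an ethyl, a methoxy or a chlorine at the same place. They also leave open whether a methyl on any other carbon of this ring would give a similar step.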